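A few compounds are considered here, and "the series" means these few. Any claim that something is new, unique, unknown or untested is made for them only; others in the source may bear on it.

Measured so far, in a physicochemical assay for pharmacokinetics; a higher number here means that the compound lasts longer, a lower number that the compound disappears faster:
Compound 1 `O=C(NCc1cccs1)N1C(=O)c2ccccc2S1(=O)=O` gives > 166 h, which is a limit of the assay and not a number.
Compound 2 `O=C(Oc1ccccc1)N1C(=O)c2ccccc2S1(=O)=O` gives > 166 h, also a limit.
Compound 3 `O=C(c1ccccc1)N1C(=O)c2ccccc2S1(=O)=O` gives > 166 h, also a limit.

Among the measured compounds shown here, compound 1 thus stands at the limit of this assay rather than at a readable half-life; (the limit of > 166 h in this assay, at which 3 of the 3 values shown sit), so no compound has a measurable number. The steps a step that the two limits leave unreadable from compound 1 to compound 2, a step that the two limits leave unreadable from compound 1 to compound 3 and a step that the two limits leave unreadable from compound 2 to compound 3 are therefore of unknown size, and none of them touches the group that separates compound 1 from compound 4. Compound 4 `COc1cccc(CNC(=O)N2C(=O)c3ccccc3S2(=O)=O)c1` differs from compound 1 by 3-methoxyphenyl in place of thiophen-2-yl on a saturated chain carbon bound to an amide-type nitrogen. For the measured compounds named here, no measured step bears on this change. Given (the limit of > 166 h in this assay, at which 3 of the 3 values shown sit), compound 4 is expected to sit at the limit as well, the step that the limit leaves unreadable from compound 1 to compound 4 being an estimate without any readable comparison. Estimated for compound 4: 200 h, range 80 h to 500 h.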

Compound 4, half-life: > 166 h
Compound 4: a limit, no number (the forecaster's own chance of this, stated with the estimate: 85%); the middle value does not contradict the limit.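

Compound 4, like compound 1, stands at a limit in this assay and not at a number; the step between them cannot be read. The compounds shown leave open the actual half-lives of compounds 1 to 4, and whether 3-methoxyphenyl in place of thiophen-2-yl changes the half-life at all.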